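Arylmethylpiperazine amides on the benzofuran ketone core

The compounds below may be only part of what the source reports. "The series", "measured", "known", "first", "only" and "open" are said of these compounds alone.

Compound 1 `CCN(CC)c1ccc2cc(C(=O)c3ccc(N4CCN(C(=O)CN5CCN(S(=O)(=O)c6ccc(C#N)cc6)CC5)CC4)cc3)oc2c1` carries a (4-cyanophenyl)sulfonyl group on the distal piperazine nitrogen. In a functional assay on SGC-7901 cells (Homo sapiens) for cytotoxicity, read by MTT assay, with a stated time of 48 h (a higher number here means a weaker inhibitor, a lower number a stronger inhibitor), compound 1 gives only a limit, > 40000 nM, which is the limit of > 40000 nM in this assay, at which 1 of the 3 values shown sits. Compound 2 `C#CCN1CCN(CC(=O)N2CCN(c3ccc(C(=O)c4cc5ccc(N(CC)CC)cc5o4)cc3)CC2)CC1` replaces that sulfonyl group with propargyl, and in this assay compound 2 gives 20100 nM; the change reads an at least 1.9-fold lower number from compound 1 to compound 2 (0.29 log units; that floor lies within the scatter). Compound 3 `CCN(CC)c1ccc2cc(C(=O)c3ccc(N4CCN(C(=O)CN5CCN(Cc6ccc(/C=C/C(=O)OC)cc6)CC5)CC4)cc3)oc2c1` extends the propargyl to an arylmethyl group, and compound 3 gives 740 nM, the step being a 27-fold lower number from compound 2 to compound 3 (1.43 log units; beyond the scatter). Compound 3 thus holds the lowest number of the two values given in this assay, with compound 2 the nearest, and compound 1 sitting at a limit.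

Compound 4 `CCN(CC)c1ccc2cc(C(=O)c3ccc(N4CCN(C(=O)CN5CCN(Cc6ccc(C#N)cc6)CC5)CC4)cc3)oc2c1` keeps the arylmethyl attachment and changes only the substituent on that ring: cyano in place of 2-(methoxycarbonyl)ethenyl on an aromatic carbon. The step from compound 2 to compound 3 shows that an arylmethyl group on this nitrogen brings a large gain over a bare ethynyl; compound 4 retains the arylmethyl, so most of that gain is expected to persist. Among the measured compounds shown here, no measured pair isolates the substituent para to a large group on that ring, so the size of the remaining shift is uncertain. The estimate for compound 4 is 1500 nM, within 500 nM to 5000 nM, corresponding to an expected step of a 2.0-fold higher number from compound 3 to compound 4 (0.31 log units; beyond the scatter).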

Compound 4, half-maximal inhibitory concentration: 26300 nM
Estimate against measurement, compound 4: 18-fold (1.24 log units) below; measured number outside the range, above it.
By their numbers in this assay, from the lowest: compound 3; then compounds 2 and 4 (each within the scatter of the next). At a limit, above all of these: compound 1.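

The arylmethyl attachment alone does not carry the gain: with the attachment unchanged, the substituent on an aromatic carbon, para to a large group, gives a 36-fold higher number from compound 3 to compound 4 (1.55 log units; beyond the scatter) in this assay. With 4-cyanophenyl at this position the result is a 1.3-fold higher number from compound 2 to compound 4 (0.12 log units; within the scatter), so this group cannot be told apart from the ethynyl of compound 2, and the earlier gain belongs to the 4-(2-(methoxycarbonyl)ethenyl)phenyl group as a whole rather than to any aryl ring at this position. Among the compounds shown here, the step of an at least 1.5-fold lower number from compound 1 to compound 4 (0.18 log units; that floor lies within the scatter) starts from a limit, the one held by compound 1, so the 4-cyanobenzyl and (4-cyanophenyl)sulfonyl groups are compared only through a floor, and nothing measured here bears on why the substituent matters so strongly.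

The compounds shown do not separate the contribution of the methyl ester from that of the ethenyl link within the substituent of compound 3. A carboxylic acid in place of the ester, or a saturated two-carbon chain in place of the ethenyl, would address these two parts, and an amine on the same ring carbon remains an open comparison.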